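A Pyridin-3-yl Replacement on the Aromatic Carbon

A few compounds are considered here, and "the series" means these few. Any claim that something is new, unique, unknown or untested is made for them only; others in the source may bear on it.

Within the data shown here, compound 2 `CC(C(=O)NCc1ccc(C(F)(F)F)cc1SCc1ccccc1)c1ccc(NS(C)(=O)=O)c(F)c1` gives 0.5 nM in an assay on CHO cells for antagonist activity at transient receptor potential cation channel subfamily V member 1 (Homo sapiens), read by FLIPR (a lower number here means a stronger inhibitor, a higher number a weaker inhibitor), the lowest of the two numbers measured so far, and its nearest neighbour is compound 1 `CC(C)COc1cc(C(F)(F)F)ccc1CNC(=O)C(C)c1ccc(NS(C)(=O)=O)c(F)c1`, which in this assay gives 0.8 nM. Compound 3 `CC(C(=O)NCc1ccc(C(F)(F)F)cc1-c1cccnc1)c1ccc(NS(C)(=O)=O)c(F)c1` has not yet been measured. It differs from compound 2 by pyridin-3-yl in place of benzylsulfanyl on an aromatic carbon, a change made on an aromatic carbon of a six-membered aromatic ring of carbon only, ortho to a large group and meta to a trifluoromethyl group. Among the measured compounds shown here, only one measured step touches this same position, a 1.6-fold lower number from compound 1 to compound 2 (0.20 log units; within the scatter), and it lay within the scatter, so two different groups there give numbers within the scatter of each other, while nothing measured speaks to a pyridin-3-yl there. A modest rise in the number is expected for compound 3, a 5.0-fold higher number from compound 2 to compound 3 (0.70 log units; beyond the scatter). Compound 3 is estimated at 2.5 nM, with a range from 0.5 nM to 15 nM.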

Compound 3, inhibition constant: 59.4 nM
Compound 3: the middle estimate sits 24-fold (1.38 log units) below what was measured, outside the stated range (above it).
By their numbers in this assay, from the lowest: compounds 2 and 1 (each within the scatter of the next); then compound 3.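

In this assay, this position proved far less forgiving than the first two compounds suggested: isobutoxy and benzylsulfanyl had given numbers within the scatter of each other, yet pyridin-3-yl gave a 120-fold higher number from compound 2 to compound 3 (2.07 log units; beyond the scatter) and a 74-fold higher number from compound 1 to compound 3 (1.87 log units; beyond the scatter). The tolerance seen with those two groups therefore does not extend to every group on this aromatic carbon, and the sizes of both steps show that this single replacement can cost most of the inhibition. No measurement at hand explains the loss.

The step from compound 2 to compound 3 changes both the ring's nitrogen and the sulfur and carbon that link the ring, so the compounds shown cannot say which of these matters. A phenyl group or a pyridin-3-ylmethylsulfanyl group at this position would separate the two.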